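Amide nitrogen substituents in the dimethoxy tetralin acetamide series

The source may hold more compounds than are shown below. What is called first, only, known or untested is meant among the compounds shown, and "the series" means these compounds.

Measured compounds:
compound 1, `COc1cc2c(cc1OC)C(CC(N)=O)CC2`, 24.6%
compound 2, `CCNC(=O)CC1CCc2cc(OC)c(OC)cc21`, 23.6%
compound 3, `CCCCCNC(=O)CC1CCc2cc(OC)c(OC)cc21`, 71.7%

All three numbers come from a functional assay on the whole organism (strain Swiss albino) for inhibition, with Mus musculus as the target, in the writhing test, with stated times of 60 min and 15 min, at a dose of 100 mg/kg by the oral route; a lower number here means less inhibition, a higher number more inhibition at the dose given (going by the name of the read-out). Compound 3 gives the highest number of the three: the step from compound 1 is a number 47.1 percentage points higher from compound 1 to compound 3 (beyond the scatter), and the step from compound 2 is a number 48.1 percentage points higher from compound 2 to compound 3 (beyond the scatter), both beyond the scatter. Compound 1 and compound 2, on the other hand, are within the scatter of each other, a number 1 percentage points lower from compound 1 to compound 2 (within the scatter).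

Compound 4, `COc1cc2c(cc1OC)C(CC(=O)NC1CCCCC1)CC2`, is not yet measured. It differs from compound 3 in one place: cyclohexyl in place of pentyl on an amide-type nitrogen. Both measured steps bear on this change only loosely, since each of them enlarged the group on the amide nitrogen from hydrogen or ethyl to pentyl and both were large. The change to cyclohexyl keeps a group of similar bulk on the nitrogen and removes nothing, so a step of a number 9.7 percentage points lower from compound 3 to compound 4 (within the scatter) is expected, which lies within the scatter. Compound 4 is therefore estimated at 62%, with a range from 35% to 82%.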

Compound 4, a percentage reported as inhibition, in the whole organism at one dose (the size of the read-out at that dose, not a potency): 44.7%
The estimate for compound 4 lay 17.3 percentage points above the measured number, and the stated range covers the measured number.
By their numbers in this assay, from the lowest: compounds 2 and 1 (each within the scatter of the next); then compound 4; then compound 3.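

In this assay, the amide nitrogen does not respond to enlargement of its substituent alone: cyclohexyl, with its ring, in place of pentyl, with no ring, gives a number 27 percentage points lower from compound 3 to compound 4 (beyond the scatter). The cyclohexyl amide still stands clear of the two with the smallest substituents, with a number 21.1 percentage points higher from compound 2 to compound 4 (beyond the scatter) for cyclohexyl in place of ethyl and a number 20.1 percentage points higher from compound 1 to compound 4 (beyond the scatter) for cyclohexyl in place of hydrogen, so a ring on this nitrogen keeps part of the gain seen with pentyl. Nothing on hand accounts for this order.

Open, going by these compounds, is whether the gap between pentyl and cyclohexyl goes with the ring itself, which a cyclopentyl or benzyl group on the same nitrogen would test. Also open, on these data alone, is whether the number rises further with a longer chain such as hexyl or octyl, or falls again.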